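Notes on the dibutylamino series: compound 2 to compound 3

A few compounds are considered here, and "the series" means these few. Any claim that something is new, unique, unknown or untested is made for them only; others in the source may bear on it.

In a functional assay (aorta) with Rattus norvegicus as the target (on this read-out lower numbers stand for stronger inhibition and higher numbers for weaker inhibition), compound 1 (`COc1ccc(CN(C)CCCCOc2ccc(S(=O)(=O)c3c(C(C)C)cn4ccccc34)cc2)cc1OC`) gives 14.6 nM and compound 2 (`CCCCN(CCCC)CCCCOc1ccc(S(=O)(=O)c2c(C(C)C)cn3ccccc23)cc1`) gives 20.2 nM as its read-out. Going by the values given here, compound 2 therefore stands within the scatter of the only other measured compound, and the pair shows no separation.

Compound 3 (`CCCCN(CCCC)CCCOc1ccc(S(=O)(=O)c2c(C(C)C)cn3ccccc23)cc1`) carries dibutylamino in place of (dibutylamino)methyl on a saturated chain carbon, three bonds along the chain from an oxygen on an aromatic ring.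

Among the compounds with values here, no measured pair isolates this change, so the size of the step in this assay has no direct precedent. Only a small step is expected, with no direction beyond the scatter, and the range is kept wide for that reason. The expected change is a 1.0-fold lower number from compound 2 to compound 3 (0.00 log units; within the scatter) on this estimate. Compound 3 is estimated at 20 nM with an expected range from 6 nM to 60 nM in this read-out.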

Compound 3, half-maximal inhibitory concentration: 21.6 nM
Compound 3: middle estimate off by 1.1-fold (0.03 log units), on the low side, within the range that was stated.
By their numbers in this assay, from the lowest: compounds 1, 2 and 3 (each within the scatter of the next).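

In this assay, going by these compounds alone, the exchange of (dibutylamino)methyl for dibutylamino on a saturated chain carbon, three bonds along the chain from an oxygen on an aromatic ring, gives a 1.1-fold higher number from compound 2 to compound 3 (0.03 log units; within the scatter) and supplies the first directly measured step at this position. The read-out of this assay therefore does not separate this pair, and the finding extends to no compounds beyond them. No accompanying data bear on the reason for this result.

Going by these compounds, the effect of a longer chain at this position remains open, since a single step cannot show whether the read-out stays level as the chain changes further. Also open, on these data alone, is whether the same exchange gives a similar step when piperidine takes the place of dibutylamino.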